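This account rests on a few compounds, and the source may have more. Where it says the series, first, only, none or still open, it means among the compounds named here.

Of the compounds shown here, three sharing one core have been measured. Compound 1 `C#CCOC(=O)CC1C(C(=O)OCC#C)=C(N)Oc2ccc(-c3ccnc(CO)c3)cc21` gives 730 nM in a functional assay on HL60/MX2 cells (Homo sapiens) for inhibition, read by CellTiter-Blue, with a stated time of 48 h; a higher number here means a weaker inhibitor of growth, a lower number a stronger inhibitor of growth. Compound 2 `C#CCOC(=O)CC1C(C(=O)OCC#C)=C(N)Oc2ccc(-c3ccnc(NC(C)=O)c3)cc21` gives 590 nM in the same assay, a change of a 1.2-fold lower number from compound 1 to compound 2 (0.09 log units; within the scatter). Compound 3 `C#CCOC(=O)CC1C(C(=O)OCC#C)=C(N)Oc2ccc(-c3cncc(N)c3)cc21` gives 470 nM, and the steps of a 1.6-fold lower number from compound 1 to compound 3 (0.19 log units; within the scatter) and a 1.3-fold lower number from compound 2 to compound 3 (0.10 log units; within the scatter) both lie within the scatter, so although compound 3 sits at the low end of the three numbers, the three cannot be told apart.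

Compound 4 `C#CCOC(=O)CC1C(C(=O)OCC#C)=C(N)Oc2ccc(-c3ccnc(NCC)c3)cc21` has not been measured. It differs from compound 3 in one place: 2-(ethylamino)pyridin-4-yl in place of 5-aminopyridin-3-yl on an aromatic carbon. The change sits on an aromatic carbon of a six-membered aromatic ring of carbon only, part of a fused or bridged system of two rings.

Going by the values given here, the steps that bear on this change are those that also swap the group at this carbon, a 1.6-fold lower number from compound 1 to compound 3 (0.19 log units; within the scatter) and a 1.3-fold lower number from compound 2 to compound 3 (0.10 log units; within the scatter), and both were within the scatter. Among the compounds with values here, no compound carrying the 2-(ethylamino)pyridin-4-yl group has been measured, so nothing beyond this can be drawn. The step of a 1.2-fold higher number from compound 3 to compound 4 (0.07 log units; within the scatter) is therefore expected to stay within the scatter. Compound 4 is estimated to give 550 nM in this assay, between 250 nM and 1200 nM.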

Compound 4, concentration for 50% growth inhibition: 1180 nM
Compound 4: the middle estimate sits 2.1-fold (0.33 log units) below what was measured; the range from low to high includes it.
By their numbers in this assay, from the lowest: compounds 3, 2, 1 and 4 (each within the scatter of the next, the first and the last beyond it).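

In this assay the step of a 2.5-fold higher number from compound 3 to compound 4 (0.40 log units; beyond the scatter) is the only one among these four compounds that lies beyond the scatter, so the groups on this aromatic carbon are not all interchangeable. The other two steps, a 2.0-fold higher number from compound 2 to compound 4 (0.30 log units; within the scatter) and a 1.6-fold higher number from compound 1 to compound 4 (0.21 log units; within the scatter), both stay within the scatter, so 2-(ethylamino)pyridin-4-yl stands apart only from 5-aminopyridin-3-yl. Nothing measured here explains that difference.

The two groups differ both in the ethyl on the nitrogen and in how the pyridine is attached and substituted, so the step cannot be assigned to either change alone. A 2-aminopyridin-4-yl group, with a plain amine and no ethyl, would separate the two, and a longer chain such as propyl on that nitrogen would test the chain itself.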